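Moving the ring nitrogen in a pyridyl benzamide series

The compounds below may be only part of what the source reports. "The series", "measured", "known", "first", "only" and "open" are said of these compounds alone.

Three compounds share a core and differ only in the aryl group on the benzamide. Compound 1 `CNC(=O)N1CCCc2ccc(NC(=O)c3ccc(-c4ccncc4)cc3)cc21` carries a pyridin-4-yl group; in a functional assay on MV4-11 cells (Homo sapiens) for antiproliferative activity, with a stated time of 6 days, tested at 1.56 uM (on this read-out higher numbers stand for a stronger effect at the one concentration tested and lower numbers for a weaker effect), compound 1 gives 37.6%, which stands second highest of the three numbers. Compound 2 `CNC(=O)N1CCCc2ccc(NC(=O)c3cccc(-c4cc[nH]n4)c3)cc21` carries a pyrazolyl group on a different position of the benzamide, and in this assay compound 2 gives 27.3%, a number beyond the scatter below that of compound 1. Compound 3 `CNC(=O)N1CCCc2ccc(NC(=O)c3cccc(-c4ccn(C)n4)c3)cc21` is the methylated counterpart of compound 2, and in this assay compound 3 gives 70.5%. For the measured compounds named here, the one step available, a number 43.2 percentage points higher from compound 2 to compound 3 (beyond the scatter), concerns methyl in place of hydrogen on an aromatic nitrogen and says nothing about where the ring nitrogen of a pyridyl group sits.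

Compound 4 `CNC(=O)N1CCCc2ccc(NC(=O)c3ccc(-c4cccnc4)cc3)cc21` differs from compound 1 by pyridin-3-yl in place of pyridin-4-yl on an aromatic carbon. Going by the values given here, no measured pair in this set mirrors that change, so the expectation rests on compound 1 alone. Compound 4 is therefore expected to stay close to compound 1, with an expected step of a number 1.6 percentage points lower from compound 1 to compound 4 (within the scatter), within the scatter. The estimate for compound 4 in this assay is 36%, with a range from 15% to 60%.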

Compound 4, a percentage reported as inhibition, at one concentration (the size of the read-out at that concentration, not a potency): 62.5%
The estimate for compound 4 lay 26.5 percentage points below the measured number; the whole stated range lies below it.
By their numbers in this assay, from the lowest: compound 2; then compound 1; then compounds 4 and 3 (each within the scatter of the next).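

In this assay, the placement of the ring nitrogen in the pyridyl group proves to matter, with a number 24.9 percentage points higher from compound 1 to compound 4 (beyond the scatter) for two compounds that have the same atoms, joined differently. The earlier step concerned only methyl in place of hydrogen on an aromatic nitrogen, whereas this one shows a response to moving the nitrogen within the ring while the group's heavy-atom count, its hydrogen-bond donor and acceptor counts and its place para to a large group stay the same. Nothing available here bears on what lies behind this step, so it stands as an observation without an explanation.

On these data alone, it remains open how pyridin-2-yl, or a plain phenyl group with no ring nitrogen, would compare with the pyridin-3-yl group of compound 4 and the pyridin-4-yl group of compound 1. Also open, as far as these compounds go, is whether an amine or a methoxy group on the pyridin-3-yl ring would preserve the number given by compound 4, which would show how much of the ring can be changed without losing the gain.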